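A few compounds are considered here, and "the series" means these few. Any claim that something is new, unique, unknown or untested is made for them only; others in the source may bear on it.

Compounds measured in an assay on isolated protein for inhibition of Nicotinamide phosphoribosyltransferase (Homo sapiens), read by fluorescence, with stated times of 5 min and 15 min; on this read-out higher numbers stand for weaker inhibition and lower numbers for stronger inhibition:
Compound 1 `Nc1ccccc1NC(=O)c1ccc(NC(=S)NCc2cccc(F)c2)cc1`. In this assay compound 1 gives > 2000 nM, a limit of the assay.
Compound 2 `Nc1ccccc1NC(=O)c1ccc(CNC(=O)c2cc3cccnc3[nH]2)cc1`. In this assay compound 2 gives > 2000 nM, a limit of the assay.
Compound 3 `Nc1ccccc1NC(=O)c1ccc(NC(=S)NCc2ccccc2F)cc1`. In this assay compound 3 gives > 2000 nM, a limit of the assay.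

Compound 2 thus stands only at a limit, as do the other two values shown (the limit of > 2000 nM in this assay, at which 3 of the 3 values shown sit). Among the measured compounds shown here, the single step within the measured set, a step that the two limits leave unreadable from compound 1 to compound 3, is unreadable between two limits, so no measured step bears on the change to compound 4. Compound 4 `Nc1ccccc1NC(=O)c1ccc(CNC(=O)c2cc3cnccc3[nH]2)cc1` differs from compound 2 by a group of 9 heavy atoms (7 carbon, 2 nitrogen; one five-membered aromatic ring with 1 hetero atom, one six-membered aromatic ring with 1 hetero atom) in place of a group of 9 heavy atoms (7 carbon, 2 nitrogen; one five-membered aromatic ring with 1 hetero atom, one six-membered aromatic ring with 1 hetero atom), on a carbonyl carbon; the two have the same atoms, joined differently. With every measured value a limit, no direction of change can be grounded; the estimate for compound 4 is 6000 nM (range 1500 nM to 30000 nM), most likely again a limit. The step that the limit leaves unreadable from compound 2 to compound 4 is the expected outcome.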

Compound 4, half-maximal inhibitory concentration: > 2000 nM
Compound 4: no number, only a limit (the forecaster's own chance of this, stated with the estimate: 85%); the middle value is on the limit's open side.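

Compound 2 and compound 4 both sit at a limit, so no step can be read between them: the limit of > 2000 nM in this assay, at which 4 of the 4 values shown sit.

The compounds shown leave open whether the two groups on the carbonyl carbon differ in inhibition at all.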